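Isopropylamino in place of amino across two cores

A few compounds are considered here, and "the series" means these few. Any claim that something is new, unique, unknown or untested is made for them only; others in the source may bear on it.

Two cores carry the same phenoxy-terminated chain. Compound 1 `N=C(N)c1ccc2oc(-c3cccc(OCCCCCOc4ccccc4)c3)cc2c1` gives 3000 nM in an ADME assay on L6 cells (Rattus norvegicus) for cytotoxicity, read by resazurin assay, with a stated time of 70 h; on this read-out higher numbers stand for weaker inhibition and lower numbers for stronger inhibition. Compound 2 `CC(C)NC(=N)c1ccc2oc(-c3cccc(OCCCCCOc4ccccc4)c3)cc2c1` differs from it by isopropyl in place of hydrogen on an amine nitrogen; in this assay compound 2 gives 10100 nM, a step of a 3.4-fold higher number from compound 1 to compound 2 (0.53 log units; beyond the scatter). Compound 3 `N=C(N)c1ccc2cc(-c3cccc(OCCCCCOc4ccccc4)c3)oc2c1` has the same atoms as compound 1 joined differently; the difference between the two cores is not broken down here. In this assay compound 3 gives 4100 nM. Compound 4 `CC(C)NC(=N)c1ccc2cc(-c3cccc(OCCCCCOc4ccccc4)c3)oc2c1` is not yet measured; against compound 3 it shows (isopropyl in place of hydrogen on an amine nitrogen), the same change at the same place as in the measured pair. The expected step is a 2.9-fold higher number from compound 3 to compound 4 (0.47 log units; beyond the scatter), resting on the measured step of a 3.4-fold higher number from compound 1 to compound 2 (0.53 log units; beyond the scatter) carrying over to the second core. Compound 4 is therefore estimated at 12000 nM, with a range from 5000 nM to 30000 nM.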

Compound 4, half-maximal inhibitory concentration: 20100 nM
The estimate for compound 4 lay 1.7-fold (0.22 log units) below the measured number, within the range that was stated.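

In this assay, isopropyl in place of hydrogen on the amine nitrogen gives a step of the same direction on the second core (a 4.9-fold higher number from compound 3 to compound 4 (0.69 log units; beyond the scatter)). These two pairs do not show that the change would carry over to any further core or alongside a different chain, and they give no cause for the step. Within this series, the step from amino to isopropylamino carries over between the two cores without a difference that can be told from scatter: the same change on two cores in this assay, a 3.4-fold higher number (0.53 log units; beyond the scatter) from compound 1 to compound 2 and a 4.9-fold higher number (0.69 log units; beyond the scatter) from compound 3 to compound 4, 1.5-fold (0.16 log units) apart, within the scatter of two such steps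

Open, going by these compounds, is whether a smaller or larger group on the same nitrogen, such as methyl or cyclohexyl, would give a step of similar size. Also open, on these data alone, is whether the step holds with a longer chain or with a carboxylic acid in place of the terminal phenoxy group.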